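From a hexyl to an isopropyl group on nitrogen

This account rests on a few compounds, and the source may have more. Where it says the series, first, only, none or still open, it means among the compounds named here.

- Compound 1 `CCN(Cc1ccc(C(=O)NO)cc1)c1ncc(-c2ccc(C)cc2)s1`: 6870 nM
- Compound 2 `Cc1ccc(-c2cnc(N(CCCCOc3ccccc3)Cc3ccc(C(=O)NO)cc3)s2)cc1`: 680 nM
- Compound 3 `CCCCCCN(Cc1ccc(C(=O)NO)cc1)c1ncc(-c2ccc(C)cc2)s1`: 4850 nM

In a functional assay on HCT-116 cells (Homo sapiens) for antiproliferative activity, read by MTT assay, with a stated time of 48 h (a lower number here means a stronger inhibitor of growth, a higher number a weaker inhibitor of growth), compound 3, which carries hexyl, stands level with the ethyl-bearing compound 1, the measured step being a 1.4-fold lower number from compound 1 to compound 3 (0.15 log units; within the scatter). The chain carrying phenoxy sets compound 2 clearly apart, with a 7.1-fold higher number from compound 2 to compound 3 (0.85 log units; beyond the scatter).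

Compound 4 `Cc1ccc(-c2cnc(N(Cc3ccc(C(=O)NO)cc3)C(C)C)s2)cc1` differs from compound 3 by one change: isopropyl in place of hexyl on a nitrogen on an aromatic ring. Here isopropyl stands in place of hexyl on a nitrogen on an aromatic ring. Compound 4 has no phenoxy, so the larger step, a 10-fold lower number from compound 1 to compound 2 (1.00 log units; beyond the scatter), offers little guidance. The closer precedent is the step within the scatter shown above, so no shift beyond the scatter is expected in this assay. The expected step is a 1.1-fold higher number from compound 3 to compound 4 (0.05 log units; within the scatter). For compound 4 the estimated value is 5500 nM, with an expected range of 2500 nM to 12000 nM.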

Compound 4, concentration for 50% growth inhibition: 7800 nM
Compound 4: middle estimate off by 1.4-fold (0.15 log units), on the low side; the range from low to high includes it.
By their numbers in this assay, from the lowest: compound 2; then compounds 3, 1 and 4 (each within the scatter of the next).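

In this assay, isopropyl on this nitrogen stands level with hexyl (a 1.6-fold higher number from compound 3 to compound 4 (0.21 log units; within the scatter)) and with the ethyl of compound 1 (a 1.1-fold higher number from compound 1 to compound 4 (0.06 log units; within the scatter)), so these three simple carbon groups give matching readings despite their different shapes and sizes. Against 4-phenoxybutyl the step is large (an 11-fold higher number from compound 2 to compound 4 (1.06 log units; beyond the scatter)), leaving compound 2 alone apart from the other three. No evidence here accounts for that gap. On these data alone, what remains open is whether the gap follows the phenoxy group itself or the chain that carries it. A benzyl group or a 4-aminobutyl chain on this nitrogen would help separate the two.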